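The source may report more compounds than this note shows. Statements on the series, on what has been measured and on what is new or still open speak of the compounds shown alone.

Compound 1 `O=C(O)Cn1c(SCCCNc2ccccc2)nc2ccccc21` gives 2690 nM in an assay on HEK293 cells for displacement of a labelled ligand from prostaglandin D2 receptor 2 (Homo sapiens); on this read-out higher numbers stand for weaker inhibition and lower numbers for stronger inhibition.
Compound 2 `CCOC(=O)CCCSc1nc2ccccc2n1CC(=O)O` gives 4410 nM in this assay.

Among the measured compounds shown here, these two values sit within the scatter of each other, the only measured step being a 1.6-fold higher number from compound 1 to compound 2 (0.21 log units; within the scatter). Compound 3 `CCOC(=O)CCCCCSc1nc2ccccc2n1CC(=O)O` differs from compound 2 by 2-(ethoxycarbonyl)ethyl in place of ethoxycarbonyl on a saturated chain carbon, three bonds along the chain from a sulfur. For the measured compounds named here, that measured step swaps a group at the same place; no measured step lengthens the chain, so nothing shows how that should read. Going by the values given here, the chain grows, but the ester end stays, and the one comparable step stayed within the scatter. Compound 3 is therefore expected to show a 1.1-fold lower number from compound 2 to compound 3 (0.04 log units; within the scatter). Compound 3 is estimated at 4000 nM, within 1500 nM to 11000 nM.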

Compound 3, half-maximal inhibitory concentration: 1010 nM
Beside the measured number, compound 3's estimate is 4.0-fold (0.60 log units) above it; measured number below the stated range.
By their numbers in this assay, from the lowest: compound 3; then compounds 1 and 2 (each within the scatter of the next).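

Anilino and ethoxycarbonyl at this position could not be told apart, so the position had not yet shown any response. Keeping the ester end and moving it further out along the chain, with 2-(ethoxycarbonyl)ethyl in place of ethoxycarbonyl, gives a 4.4-fold lower number from compound 2 to compound 3 (0.64 log units; beyond the scatter) in this assay and shows that the position does respond. The same group in place of anilino gives a 2.7-fold lower number from compound 1 to compound 3 (0.43 log units; beyond the scatter) as well, and nothing measured here accounts for either step.

Going by these compounds, whether a still longer chain would lower the number further remains open, as does whether a carboxylic acid or an amine at the chain end would keep the lower number of compound 3.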